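Swapping a furan for a benzothiophene on an inactive sulfonamide

The compounds below may be only part of what the source reports. "The series", "measured", "known", "first", "only" and "open" are said of these compounds alone.

Measured compounds:
Compound 1, `Cc1ccc(S(=O)(=O)Nc2ccc(Br)c3ccccc23)cc1`, gives "not active" (no number reported).
Compound 2, `Cc1ccc(S(=O)(=O)Nc2ccc(-c3ccco3)c3cccnc23)cc1`, gives "not active" (no number reported).
Compound 3, `Cc1ccc(S(=O)(=O)Nc2ccc(-c3ccsc3)c3cccnc23)cc1`, gives 4090 nM.

All three share a sulfonamide core and were tested in a functional assay on NCI-H1299 cells (Homo sapiens) for antiproliferative activity, with a stated time of 2 days; a higher number here means a weaker inhibitor, a lower number a stronger inhibitor. Compound 2 stands without a single number: it is reported as "not active" (no number reported), as is compound 1, while only compound 3 delivers a value, 4090 nM.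

Compound 4, `Cc1ccc(S(=O)(=O)Nc2ccc(-c3cc4ccccc4s3)c3cccnc23)cc1`, arises from compound 2 by one change: 1-benzothiophen-2-yl in place of furan-2-yl on an aromatic carbon. Among the compounds with values here, no measured pair shows this step, so its size is unknown. What the data offer is that compound 3, a close relative carrying a five-membered sulfur ring, gives a number where compound 2 does not. On that basis compound 4 is expected to gain activity over compound 2, perhaps landing near compound 3, though a weak or absent effect remains plausible. The estimated value for compound 4 in this assay is 3500 nM, with a range from 800 nM to 15000 nM.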

Compound 4, half-maximal inhibitory concentration: "not active" (no number reported)
Compound 4 has no reported number here; no gap can be computed for the estimate.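

Within the data shown here, compound 4, like compound 2, is reported as not active, with no number, so no step between them can be read from this assay. The compounds shown leave open whether furan-2-yl and 1-benzothiophen-2-yl differ at all in their effect on activity. Nothing measured here explains this result.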